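The source may hold more compounds than are shown below. What is called first, only, known or untested is meant among the compounds shown, and "the series" means these compounds.

Measured compounds:
compound 1, `Cn1cnnc1SCCc1nnc(SCC(=O)Nc2ccc(Cl)cc2)o1`: > 500 ug/mL
compound 2, `Cn1cnnc1SCCc1nnc(SCC(=O)Nc2nc3ccc([N+](=O)[O-])cc3s2)o1`: > 500 ug/mL

In an ADME assay on NIH3T3 cells (Mus musculus) for cytotoxicity, read by MTT assay, with a stated time of 24 h (a lower number here means a stronger inhibitor, a higher number a weaker inhibitor), compound 1 reaches only the limit of the test, > 500 ug/mL. Compound 2 also stops at the limit, > 500 ug/mL. Both results sit at the limit of > 500 ug/mL in this assay, at which 2 of the 2 values shown sit, so compound 1 stands at the limit alongside the other measured compound, with no number of its own.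

Compound 3, `Cn1cnnc1SCCc1nnc(SCC(=O)Nc2ccccc2)o1`, differs from compound 1 by hydrogen in place of chloro on an aromatic carbon. Going by the values given here, no step between measured compounds is available, and no shift beyond the usual scatter is expected in this assay. Compound 3 is therefore expected to give about 700 ug/mL, between 350 ug/mL and 1500 ug/mL, most likely again as a limit. The expected step that the limit leaves unreadable from compound 1 to compound 3 lies within the scatter.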

Compound 3, half-maximal inhibitory concentration: > 500 ug/mL
Compound 3 gave a limit, no number; the forecaster's own chance of this, stated with the estimate: 85%; the middle value lies beyond the limit too.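

No step from compound 1 to compound 3 can be read, as each result is only a limit: the limit of > 500 ug/mL in this assay, at which 3 of the 3 values shown sit.

The compounds shown leave open whether hydrogen in place of chloro changes the result at all, since none of them has a number of its own.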